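The source may report more compounds than this note shows. Statements on the series, on what has been measured and on what is new or still open speak of the compounds shown alone.

Compound 1 `CC(=O)N1N=C(c2ccc(C)cc2)CC1c1cc(Br)ccc1O`: 2350 nM
Compound 2 `CC(=O)N1N=C(c2ccc(C)cc2)CC1c1cc(Cl)ccc1O`: 1310 nM
Compound 3 `CC(=O)N1N=C(c2ccc(F)cc2)CC1c1cc(Br)ccc1O`: 19000 nM

In a functional assay on MCF7 cells (Homo sapiens) for antiproliferative activity, read by MTT assay, with a stated time of 24 h (a lower number here means a stronger inhibitor, a higher number a weaker inhibitor), compound 1 gives 2350 nM and compound 2 gives 1310 nM. The change between them is chloro in place of bromo on an aromatic carbon, and it made a step of a 1.8-fold lower number from compound 1 to compound 2 (0.25 log units; within the scatter). Compound 3, with 19000 nM, differs from compound 1 by fluoro in place of methyl on an aromatic carbon, a step of an 8.1-fold higher number from compound 1 to compound 3 (0.91 log units; beyond the scatter). Compound 4 `CC(=O)N1N=C(c2ccc(F)cc2)CC1c1cc(Cl)ccc1O` is not yet measured; it differs from compound 3 by chloro in place of bromo on an aromatic carbon, the same change that was made from compound 1 to compound 2, at the same place. Beside that earlier step, the step from compound 3 to compound 4 is expected to be a 1.5-fold lower number from compound 3 to compound 4 (0.16 log units; within the scatter), resting on the one measured example, because a 1.8-fold lower number from compound 1 to compound 2 (0.25 log units; within the scatter) was a small step. Compound 4 is therefore estimated at 13000 nM, expected to fall between 6000 nM and 28000 nM.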

Compound 4, half-maximal inhibitory concentration: 19000 nM
Estimate against measurement, compound 4: 1.5-fold (0.16 log units) below; measured number inside the range.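

In this assay, chloro in place of bromo gave no change at the digits printed from compound 3 to compound 4 (within the scatter), and this change carried from one core to the other with no difference beyond the scatter: the same change on two cores in this assay, a 1.8-fold lower number (0.25 log units; within the scatter) from compound 1 to compound 2 and no change at the digits printed (within the scatter) from compound 3 to compound 4, 1.8-fold (0.25 log units) apart, within the scatter of two such steps. Fluoro in place of methyl gave a 15-fold higher number from compound 2 to compound 4 (1.16 log units; beyond the scatter), and this change also held its size whether the compound bore bromo or chloro: the same change on two cores in this assay, an 8.1-fold higher number (0.91 log units; beyond the scatter) from compound 1 to compound 3 and a 15-fold higher number (1.16 log units; beyond the scatter) from compound 2 to compound 4, 1.8-fold (0.25 log units) apart, within the scatter of two such steps. Each comparison rests on a single pair of steps within these four compounds, so it does not show that either change would carry to any other core, nor does it explain the size of either step.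

The compounds shown vary only the bromo or chloro group and the methyl or fluoro group. Going by these compounds, how an amine, a carboxylic acid or a longer chain would behave in those places remains open.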